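The compounds below may be only part of what the source reports. "The series", "measured", "known", "first", "only" and "open" are said of these compounds alone.

Measured so far:
compound 1 `O=C(Nc1cccc(-n2cc(-c3ccncc3)c(-c3ccc(Cl)c(O)c3)n2)c1)Nc1ccc(Cl)c(Cl)c1`: 1460 nM
compound 2 `COc1cc(-c2nn(-c3cccc(NC(=O)c4ccc(Cl)c(C(F)(F)F)c4)c3)cc2-c2ccncc2)ccc1Cl`: 4750 nM

Of the compounds shown here, two have been measured in a functional assay on SW-620 cells (Homo sapiens) for inhibition, read by sulforhodamine B assay, with a stated time of 48 h; a lower number here means a stronger inhibitor of growth, a higher number a weaker inhibitor of growth. Compound 2 `COc1cc(-c2nn(-c3cccc(NC(=O)c4ccc(Cl)c(C(F)(F)F)c4)c3)cc2-c2ccncc2)ccc1Cl` gives 4750 nM in this assay, the highest of the two numbers. The nearest is compound 1 `O=C(Nc1cccc(-n2cc(-c3ccncc3)c(-c3ccc(Cl)c(O)c3)n2)c1)Nc1ccc(Cl)c(Cl)c1`, which gives 1460 nM in this assay, a gap beyond the scatter. Among the compounds with values here, the two compounds differ in several places at once, so no single counted step connects them; their values show only that compound 2 is the weaker growth inhibitor of the pair.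

The next compound, compound 3 `COc1cc(-c2nn(-c3cccc(NC(=O)c4cccc(C(F)(F)F)c4)c3)cc2-c2ccncc2)ccc1Cl`, departs from compound 2 in one place: hydrogen in place of chloro on an aromatic carbon. Within the data shown here, no measured pair carries this change, so no counted step guides the expectation; the single heavy atom is removed from the six-membered aromatic ring of carbon only, leaving the trifluoromethyl group in place. The expected step of a 1.7-fold higher number from compound 2 to compound 3 (0.23 log units; within the scatter) is a moderate move toward a higher number, somewhat beyond the scatter. Compound 3 is estimated at 8000 nM, with a range from 3000 nM to 22000 nM.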

Compound 3, concentration for 50% growth inhibition: 2310 nM
The estimate for compound 3 lay 3.5-fold (0.54 log units) above the measured number; the measured number lies below the stated range.
By their numbers in this assay, from the lowest: compounds 1 and 3 (each within the scatter of the next); then compound 2.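

Replacing chloro with hydrogen on the carbon ortho to a trifluoromethyl group and para to a large group gives a 2.1-fold lower number from compound 2 to compound 3 (0.31 log units; beyond the scatter) in this assay and makes the 3-(trifluoromethyl)phenyl amide the stronger growth inhibitor of this pair. Chloro at this position is therefore not required for growth inhibition in this pair, and its removal brings a modest gain while the hydrogen-bond donor and acceptor counts and net charge stay unchanged. Nothing available explains the direction of this step.

Going by these compounds, this reading rests on a single pair, so it remains open whether the same replacement gives a similar step when other parts of the molecule differ. On these data alone, it is also open how a fluoro, a nitrile or an amine on this carbon would compare with hydrogen and chloro, and what the trifluoromethyl group, present in both compounds of the pair, contributes to growth inhibition.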